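Amide nitrogen on the shared core: butyl to tert-butyl

The source may report more compounds than this note shows. Statements on the series, on what has been measured and on what is new or still open speak of the compounds shown alone.

In a functional assay on PC-3 cells (Homo sapiens) for inhibition, read by sulforhodamine B assay, with a stated time of 72 h (on this read-out higher numbers stand for weaker inhibition and lower numbers for stronger inhibition), compound 1 `CC1CN(C(=O)c2c(N)sc(-c3ccc(Cl)cc3)c2-c2ccc(Cl)cc2)CCN1` gives 7210 nM and compound 2 `CCCCNC(=O)c1c(N)sc(-c2ccc(Cl)cc2)c1-c1ccc(Cl)cc1` gives 17800 nM, the higher of the two numbers. Compound 3 `CC(C)(C)NC(=O)c1c(N)sc(-c2ccc(Cl)cc2)c1-c1ccc(Cl)cc1` carries tert-butyl in place of butyl on an amide-type nitrogen, with the same atoms joined differently: tert-butyl in place of butyl on an amide-type nitrogen. Among the compounds with values here, the only measured step that bears on this is modest, a 2.5-fold higher number from compound 1 to compound 2 (0.39 log units; beyond the scatter), and it exchanges a different group on the carbonyl carbon. From the compounds shown here alone, no step beyond the scatter is expected in this assay, and the direction remains open. The estimated 1.2-fold lower number from compound 2 to compound 3 (0.07 log units; within the scatter) stays small. For compound 3 the expected value is 15000 nM, with an estimated range of 7000 nM to 32000 nM.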

Compound 3, half-maximal inhibitory concentration: 15100 nM
Beside the measured number, compound 3's estimate is 1.0-fold (0.00 log units) below it, within the range that was stated.
By their numbers in this assay, from the lowest: compound 1; then compounds 3 and 2 (each within the scatter of the next).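

In this assay, tert-butyl in place of butyl on the amide-type nitrogen gives a 1.2-fold lower number from compound 2 to compound 3 (0.07 log units; within the scatter) so the two arrangements of these four carbons are not told apart here. The 3-methylpiperazin-1-yl amide keeps its edge over this second open-chain amide, with a 2.1-fold higher number from compound 1 to compound 3 (0.32 log units; beyond the scatter) on the same carbonyl carbon. No measurement at hand gives a reason for either step.

From the compounds shown here alone, whether a longer chain, or a chain ending in an amine or a carboxylic acid, would move the number at this nitrogen stays open. So does which part of 3-methylpiperazin-1-yl goes with the lower number of compound 1.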